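From Cyclopropyl to Oxolan-2-yl: What to Expect

This account rests on a few compounds, and the source may have more. Where it says the series, first, only, none or still open, it means among the compounds named here.

Measured compounds:
Compound 1, `Cc1cc2nc(-c3nccs3)n(-c3ccc4c(N)nc(N)nc4c3)c2cc1C`, gives 93 nM in an assay on isolated protein for inhibition of Dihydrofolate reductase (Homo sapiens), read by spectrophotometry, using NADPH, with a stated time of 10 min; a lower number here means a stronger inhibitor, a higher number a weaker inhibitor.
Compound 2, `Cc1cc2nc(C3CC3)n(-c3ccc4c(N)nc(N)nc4c3)c2cc1C`, gives 1160 nM in this assay.

Compound 2 holds the higher of the two numbers and is thus the weaker inhibitor of the pair; the gap to it is a 12-fold higher number from compound 1 to compound 2 (1.10 log units; beyond the scatter). Compound 3, `Cc1cc2nc(C3CCCO3)n(-c3ccc4c(N)nc(N)nc4c3)c2cc1C`, has not yet been measured. It differs from compound 2 in one place: oxolan-2-yl in place of cyclopropyl on an aromatic carbon. Going by the values given here, only one measured step concerns this position, a 12-fold higher number from compound 1 to compound 2 (1.10 log units; beyond the scatter), and it shows that the group there can move the number a long way. That step exchanged an aromatic ring for cyclopropyl; here a five-membered non-aromatic ring with one oxygen enters instead, so the direction is less certain. A modest move toward a lower number is expected, possibly within the scatter. The expected step is a 1.8-fold lower number from compound 2 to compound 3 (0.25 log units; within the scatter). Compound 3 is therefore estimated at 650 nM, with a range from 200 nM to 2000 nM.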

Compound 3, inhibition constant: 749 nM
For compound 3 the middle estimate is 1.2-fold (0.06 log units) below the measured one; low and high end bracket the measured number.
By their numbers in this assay, from the lowest: compound 1; then compounds 3 and 2 (each within the scatter of the next).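

Exchanging one non-aromatic ring for another at this position gives a step within the scatter (a 1.5-fold lower number from compound 2 to compound 3 (0.19 log units; within the scatter)), so in this assay cyclopropyl and oxolan-2-yl cannot be told apart, even though oxolan-2-yl has more heavy atoms and a hydrogen-bond acceptor. The gap to the aromatic group remains beyond the scatter (an 8.1-fold higher number from compound 1 to compound 3 (0.91 log units; beyond the scatter)), so among these three compounds, 1,3-thiazol-2-yl gives the lowest number and neither non-aromatic ring comes close to it. Nothing available explains why these groups differ.

Only one aromatic group is shown here, so it remains open whether a phenyl or furan-2-yl ring would match 1,3-thiazol-2-yl. Also open, going by these compounds, is what a ring carrying an amine, such as pyrrolidin-2-yl, would do at this position.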